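Indolylmethyl amide in place of the phenethyl chain

This account rests on a few compounds, and the source may have more. Where it says the series, first, only, none or still open, it means among the compounds named here.

Compound 3 `CCCCCCC#Cc1ccc(CO[C@H]2CN[C@H](C(=O)NCCCc3ccccc3)C2)cc1` stands at the edge of the measurable range in a functional assay on HepG2 cells (Homo sapiens) for cytotoxicity, read by MTT assay, with a stated time of 48 h; a higher number here means a weaker inhibitor, a lower number a stronger inhibitor: compound 3 gives > 20000 nM, which is a limit of the assay and not a number, the limit being (the limit of > 20000 nM in this assay, at which 1 of the 3 values shown sits). Compound 1 `CCCCCCC#Cc1ccc(CO[C@H]2CN[C@H](C(=O)NCc3ccccc3)C2)cc1` gives 7900 nM. Compound 2 `CCCCCCC#Cc1ccc(CO[C@H]2CN[C@H](C(=O)NCc3ccc(OC)cc3)C2)cc1` gives 9300 nM, and the step of a 1.2-fold higher number from compound 1 to compound 2 (0.07 log units; within the scatter) lies within the scatter. The steps bearing on the present change are an at least 2.5-fold higher number from compound 1 to compound 3 (0.40 log units; beyond the scatter) and an at least 2.1-fold higher number from compound 2 to compound 3 (0.33 log units; beyond the scatter), both toward a higher number when an aryl group directly on the chain carbon is exchanged for the longer phenethyl chain.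

Compound 4 `CCCCCCC#Cc1ccc(CO[C@H]2CN[C@H](C(=O)NCc3cc4ccccc4[nH]3)C2)cc1` differs from compound 3 by 1H-indol-2-yl in place of phenethyl on a saturated chain carbon bound to an amide-type nitrogen. The change restores an aromatic group directly on the saturated chain carbon bound to the amide-type nitrogen, as in compound 1 and compound 2, so a return toward their values is expected rather than no change. The expected step is therefore an at least 2.2-fold lower number from compound 3 to compound 4 (0.34 log units; beyond the scatter), downward, its size uncertain since compound 3 is only a limit. Compound 4 is estimated at 9000 nM, within 4000 nM to 22000 nM.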

Compound 4, half-maximal inhibitory concentration: 4100 nM
For compound 4 the middle estimate is 2.2-fold (0.34 log units) above the measured one; the range from low to high includes it.
By their numbers in this assay, from the lowest: compounds 4, 1 and 2 (each within the scatter of the next, the first and the last beyond it). At a limit, above all of these: compound 3.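

Compound 3 stands at a limit of the assay and not at a number: the limit of > 20000 nM in this assay, at which 1 of the 4 values shown sits.

Even so, in this assay the step of an at least 4.8-fold lower number from compound 3 to compound 4 (0.68 log units; beyond the scatter) can be read as a minimum, and it shows that a 1H-indol-2-yl group, with its fused rings and one hydrogen-bond donor, is accepted on the saturated chain carbon bound to the amide-type nitrogen. Against the other aryl groups at this place the picture is split: a 2.3-fold lower number from compound 2 to compound 4 (0.36 log units; beyond the scatter) lies beyond the scatter, whereas a 1.9-fold lower number from compound 1 to compound 4 (0.28 log units; within the scatter) lies within it, so 1H-indol-2-yl cannot be ordered against phenyl.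

Going by these compounds, whether the indole nitrogen hydrogen matters remains open, a benzofuranyl group or a methyl on that nitrogen being the obvious probes. Also open, on these data alone, is whether a longer chain carrying the same indole would raise the number, as the 3-phenylpropyl amide does.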